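The compounds below may be only part of what the source reports. "The series", "measured", "known", "first", "only" and "open" are said of these compounds alone.

Of the compounds shown here, three have been measured in an assay on HEK293 cells for positive allosteric modulation of metabotropic glutamate receptor 3 (Rattus norvegicus), read by thallium flux, with a stated time of 2.5 min; on this read-out lower numbers stand for smaller maximal responses and higher numbers for larger maximal responses. Compound 1 `Cc1c(OCCCCOc2ccccc2C(=O)O)ccc(C(=O)CC2CCCC2)c1O` reaches 32.9%, compound 2 `Cc1c(OCCCCOc2ccc(C(=O)O)c(Cl)c2)ccc(C(=O)CC2CCCC2)c1O` reaches 40%, and compound 3 `Cc1c(OCCCCOc2ccc(C(=O)O)c(Cl)c2)ccc(C(=O)CC(C)C)c1O` reaches 49.5%. The step of a number 7.1 percentage points lower from compound 2 to compound 1 (within the scatter) comes from swapping one aromatic ring for another: 2-carboxyphenyl in place of 4-carboxy-3-chlorophenyl on an oxygen on a saturated carbon. The step of a number 9.5 percentage points higher from compound 2 to compound 3 (within the scatter) comes from a change at the other end of the molecule: isopropyl in place of cyclopentyl on a saturated chain carbon bound to a carbonyl carbon. Neither step is large enough to stand out from repeat measurements of this kind.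

Compound 4 `Cc1c(OCCCCOc2ccccc2C(=O)O)ccc(C(=O)CC(C)C)c1O` is still to be measured. It differs from compound 3 by 2-carboxyphenyl in place of 4-carboxy-3-chlorophenyl on an oxygen on a saturated carbon, the same change that was made from compound 2 to compound 1, where it gave a number 7.1 percentage points lower from compound 2 to compound 1 (within the scatter). The cores of compound 2 and compound 3 differ by isopropyl in place of cyclopentyl on a saturated chain carbon bound to a carbonyl carbon. Because that earlier step a number 7.1 percentage points lower from compound 2 to compound 1 (within the scatter) stayed within the usual scatter, the same change on compound 3 is expected to move the value only a little, giving an estimated step of a number 6.5 percentage points lower from compound 3 to compound 4 (within the scatter). Compound 4 is expected to reach about 43%, with a likely range from 30% to 56%.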

Compound 4, largest response reached (reported as percent of maximum), in percent of the reference or control that the assay uses: 28.1%
The estimate for compound 4 lay 14.9 percentage points above the measured number, and the stated range ends above it.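

In this assay, 2-carboxyphenyl in place of 4-carboxy-3-chlorophenyl gives a number 21.4 percentage points lower from compound 3 to compound 4 (beyond the scatter), so the size of this change did not carry over from one core to the other: the same change on two cores in this assay, a number 7.1 percentage points lower (within the scatter) from compound 2 to compound 1 and a number 21.4 percentage points lower (beyond the scatter) from compound 3 to compound 4, 14.3 percentage points apart, beyond the scatter of two such steps

Seen from the other end of the molecule, isopropyl in place of cyclopentyl gives a number 4.8 percentage points lower from compound 1 to compound 4 (within the scatter), and this change also depends on the group at the far end: the same change on two cores in this assay, a number 9.5 percentage points higher (within the scatter) from compound 2 to compound 3 and a number 4.8 percentage points lower (within the scatter) from compound 1 to compound 4, 14.3 percentage points apart, beyond the scatter of two such steps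

So in these four compounds the effects of the two changes do not simply add up, but this single set of four shows neither why that happens nor whether it would hold on any other core.

Still open, as far as these compounds go, is how the ring swap behaves with an ethyl or a phenyl group in place of the isopropyl or cyclopentyl. Also open, from the compounds shown here alone, is what a fluorine or a methyl in place of the chlorine, or a longer chain between the two oxygens, would do to the maximal response.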